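A few compounds are considered here, and "the series" means these few. Any claim that something is new, unique, unknown or untested is made for them only; others in the source may bear on it.

Measured so far in a functional assay on PC-3 cells (Homo sapiens) for antiproliferative activity, read by MTT assay, with a stated time of 72 h; a higher number here means a weaker inhibitor, a lower number a stronger inhibitor: compound 1 `CC(C)=CC(=O)Nc1cc2c(N3CCc4ccccc43)ncnc2cc1O[C@@H]1CCOC1` gives 4620 nM; compound 2 `CC(C)/C=C/C(=O)Nc1cc2c(N3CCc4ccccc43)ncnc2cc1O[C@@H]1CCOC1` gives 11200 nM; compound 3 `O=C(/C=C/CN1CCCC1)Nc1cc2c(N3CCc4ccccc43)ncnc2cc1O[C@@H]1CCOC1` gives 1510 nM.

Compound 3 holds the lowest number of the three: a 3.1-fold lower number from compound 1 to compound 3 (0.49 log units; beyond the scatter) and a 7.4-fold lower number from compound 2 to compound 3 (0.87 log units; beyond the scatter), while between the other two a 2.4-fold higher number from compound 1 to compound 2 (0.38 log units; beyond the scatter). Compound 4 `CN1CCN(C/C=C/C(=O)Nc2cc3c(N4CCc5ccccc54)ncnc3cc2O[C@@H]2CCOC2)CC1` differs from compound 3 by 4-methylpiperazin-1-yl in place of pyrrolidin-1-yl on a saturated chain carbon bound to a double-bonded chain carbon. Among the measured compounds shown here, no measured step swaps one such ring for another; the steps ending at compound 3 show only that the ring-bearing chain gave a lower number than the two plain alkenyl chains. The step from compound 3 to compound 4 is therefore expected to be small in this assay, a 1.0-fold lower number from compound 3 to compound 4 (0.00 log units; within the scatter), with no direction beyond the scatter favoured. Compound 4 is estimated at 1500 nM, range 600 nM to 4000 nM.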

Compound 4, half-maximal inhibitory concentration: 4210 nM
The estimate for compound 4 lay 2.8-fold (0.45 log units) below the measured number, and the stated range ends below it.
By their numbers in this assay, from the lowest: compound 3; then compounds 4 and 1 (each within the scatter of the next); then compound 2.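

In this assay, the identity of the ring on this saturated chain carbon counts: 4-methylpiperazin-1-yl in place of pyrrolidin-1-yl gives a 2.8-fold higher number from compound 3 to compound 4 (0.45 log units; beyond the scatter), so a ring-bearing chain alone does not secure the number of compound 3. Against the plain alkenyl chains the result splits, with a 2.7-fold lower number from compound 2 to compound 4 (0.42 log units; beyond the scatter) for the isopropyl-bearing chain and a 1.1-fold lower number from compound 1 to compound 4 (0.04 log units; within the scatter) for 2-methylprop-1-en-1-yl. Open, as far as these compounds go, is whether piperidin-1-yl, morpholin-4-yl or an open-chain dimethylamino group would stand with compound 3 or compound 4 here. No evidence on hand bears on this step.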